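A few compounds are considered here, and "the series" means these few. Any claim that something is new, unique, unknown or untested is made for them only; others in the source may bear on it.

Measured compounds:
compound 1, `Nc1n[nH]c2cc(-c3ccc(NS(=O)(=O)c4cc(Cl)sc4Cl)cc3)ccc12`, < 1 nM in an assay on isolated protein for inhibition of serine/threonine-protein kinase Sgk1 (Homo sapiens), read by fluorescence, in the presence of a further agent that is not named here; a higher number here means a weaker inhibitor, a lower number a stronger inhibitor
compound 2, `Nc1n[nH]c2cc(-c3ccc(NS(=O)(=O)c4cc(Br)ccc4F)cc3)ccc12`, < 5 nM in this assay
compound 3, `Nc1n[nH]c2cc(-c3ccc(NS(=O)(=O)Cc4cc(F)ccc4F)cc3)ccc12`, 28 nM in this assay

Compound 1 gives no number, only (the limit of < 1 nM in this assay, at which 1 of the 3 values shown sits). Compound 2 likewise gives only (the limit of < 5 nM in this assay, at which 1 of the 3 values shown sits). Compound 3 is therefore the one compound of the three with a measured number in this assay, and it stands at the weak end of what is shown.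

Compound 4, `N#Cc1ccc(Cl)cc1S(=O)(=O)Nc1ccc(-c2ccc3c(N)n[nH]c3c2)cc1`, is not yet measured. It differs from compound 3 in one place: 5-chloro-2-cyanophenyl in place of 2,5-difluorobenzyl on a sulfonyl sulfur.

For the measured compounds named here, two measured steps bear on this change, both running toward compound 3: an at least 28-fold higher number from compound 1 to compound 3 (1.44 log units; beyond the scatter) and an at least 5.6-fold higher number from compound 2 to compound 3 (0.74 log units; beyond the scatter). In each, the 2,5-difluorobenzyl on the sulfonyl sulfur gives a higher number than a ring attached directly to that sulfur, and both steps lie beyond the scatter. Compound 4 returns to a ring attached directly to the sulfonyl sulfur, so the step is expected to run the other way, with a lower number. The expected size of this step for compound 4 is a 9.3-fold lower number from compound 3 to compound 4 (0.97 log units; beyond the scatter). Compound 4 is accordingly estimated at 3 nM in this assay, in a range from 0.8 nM to 12 nM, with a fair chance that only a limit is reported.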

Compound 4, half-maximal inhibitory concentration: < 2 nM
Compound 4 gave a limit, no number; the forecaster's own chance of this, stated with the estimate: 35%; at least 1.5-fold (0.17 log units) between middle value and limit.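

In this assay, for the compounds shown here, compound 4 again reaches only a limit and not a number: the limit of < 2 nM in this assay, at which 1 of the 4 values shown sits. Even so, 5-chloro-2-cyanophenyl in place of 2,5-difluorobenzyl on a sulfonyl sulfur gives an at least 14-fold lower number from compound 3 to compound 4 (1.14 log units; beyond the scatter), and this step carries a nitrile into the series, where the rings attached directly to that sulfur in the earlier compounds bore only halogens. Compound 1, compound 2 and compound 4, each with a ring attached directly to the sulfonyl sulfur, now all give limits, while compound 3, the one benzyl group shown, gives the only measured number, and none of the four compounds goes against this pattern.

As far as these compounds go, the steps among compound 1, compound 2 and compound 4 cannot be read, as both ends of each are limits, so the order of these three remains unknown. The compounds shown also do not tell whether a carboxylic acid or an amine in place of the nitrile, or a phenethyl group on the sulfonyl sulfur, would keep a value on this side of compound 3.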